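The source may hold more compounds than are shown below. What is called first, only, known or untested is meant among the compounds shown, and "the series" means these compounds.

Working notes on the series. In a functional assay on HCT-116 cells (Homo sapiens) for cytotoxicity, read by hypoxanthine incorporation, with a stated time of 72 h, tested at 10 uM (a lower number here means less inhibition of growth, a higher number more inhibition of growth at the concentration tested), compound 1 `CC(C)[C@H]1NC(=O)[C@@H](Cc2ccccc2)N(C)C(=O)[C@H](Cc2ccccc2)NC(=O)[C@H](COCc2ccccc2)NC(=O)[C@H](CC2CCCCC2)NC1=O` gives 93%, while compound 2 `CC(C)[C@H]1NC(=O)[C@@H](Cc2ccccc2)N(C)C(=O)[C@H](Cc2ccccc2)NC(=O)[C@H](CO)NC(=O)[C@H](CC2CCCCC2)NC1=O`, which carries hydrogen in place of benzyl on an oxygen on a saturated carbon, gives 18%. Compound 3 `CC(C)C[C@@H]1NC(=O)[C@H](CCCNC(=O)OCc2ccccc2)NC(=O)[C@H](C(C)C)NC(=O)[C@H](CC(C)C)NC(=O)[C@@H](Cc2ccc(O)cc2)NC1=O` has a core other than that of compound 1, and compound 3 gives 0%, the lowest of the three numbers.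

Compound 4 `CC(C)C[C@@H]1NC(=O)[C@H](CCCN)NC(=O)[C@H](C(C)C)NC(=O)[C@H](CC(C)C)NC(=O)[C@@H](Cc2ccc(O)cc2)NC1=O` differs from compound 3 by hydrogen in place of benzyloxycarbonyl on an amine nitrogen.

Within the data shown here, only one measured step bears on this change: a number 75 percentage points lower from compound 1 to compound 2 (beyond the scatter). It also removes a group holding a benzyl, but from an oxygen and on another core, so it is only a loose guide. Its large size and downward direction cannot simply be carried over, since compound 3 already reads 0% and leaves no visible room for a further fall. Among the measured compounds shown here, no pair on the core of compound 3 has been measured, so a rise cannot be supported either.

No step beyond the scatter is therefore expected in this assay. The expected step is a number 4 percentage points higher from compound 3 to compound 4 (within the scatter). For compound 4 the estimated value is 4%, with an expected range from 0% to 20%.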

Compound 4, percent growth inhibition at one concentration: 0%
For compound 4 the middle estimate is 4 percentage points above the measured one; measured number inside the range.
By their numbers in this assay, from the lowest: compounds 3 and 4 (each within the scatter of the next); then compound 2; then compound 1.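

In this assay the exchange of benzyloxycarbonyl for hydrogen on an amine nitrogen gives no change at the digits printed from compound 3 to compound 4 (within the scatter) and is the only such pair shown on the core of compound 3. Among these compounds, on this core neither the carbamate bearing the benzyloxycarbonyl group nor the free amine raises growth inhibition above the lowest reading of the series, so the large step of a number 75 percentage points lower from compound 1 to compound 2 (beyond the scatter) on the core of compound 1 has no visible counterpart here, although a further fall could not show at this reading. No measurement at hand accounts for either reading or for the contrast between the two pairs.

Still open, going by these compounds, is whether any group on this amine nitrogen can raise the reading on this core, for instance an acetyl group, a simple benzyl group or a guanidine, or whether a longer chain or a carboxylic acid in place of the amine would do so. Also open, on these data alone, is whether the benzyl ether that separates compound 1 from compound 2 would give any growth inhibition if carried on the core of compound 3.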